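Tolerability notes on a diaryl-amine series with a shared core

The source may hold more compounds than are shown below. What is called first, only, known or untested is meant among the compounds shown, and "the series" means these compounds.

The series is read in an ADME assay on MT2 cells (Homo sapiens) for cytotoxicity, read by MTT assay; a higher number here means that more compound is tolerated, a lower number that less compound is tolerated. Compound 1 `Fc1cccc(F)c1Cc1cnc(Nc2ccc(CCOc3ccncc3)cc2)o1` gives 11000 nM in this assay. Compound 3 `Fc1cccc(F)c1Cc1cnc(Nc2ccc(Oc3cccnc3)c(Cl)c2)o1` gives 16000 nM in this assay, a number within the scatter of the value of compound 1, so the two are treated as equal. Compound 2 `Clc1cccc(Cl)c1Cc1nnc(Nc2ccc(COCc3ccccn3)cc2)o1` reaches only the limit of this assay, > 100000 nM, and no number is available for it; the limit is noted as the limit of > 100000 nM in this assay, at which 1 of the 3 values shown sits. Compound 1 thus stands among two closely similar numbers, with a third value that is a limit rather than a number.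

Compound 4 `N#Cc1ccc(Nc2ncc(Cc3c(F)cccc3F)o2)cc1` has not yet been measured in this assay. It differs from compound 1 in one place: cyano in place of 2-((pyridin-4-yl)oxy)ethyl on an aromatic carbon. Within the data shown here, no measured step of this kind exists, so the size of the step is open. The expectation for compound 4 is a modest move toward higher tolerability, a 1.8-fold higher number from compound 1 to compound 4 (0.26 log units; within the scatter), giving an estimate of 20000 nM, within 6000 nM to 70000 nM.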

Compound 4, half-maximal cytotoxic concentration: 7400 nM
Compound 4: middle estimate off by 2.7-fold (0.43 log units), on the high side; the measured number falls inside the stated range.
By their numbers in this assay, from the lowest: compounds 4, 1 and 3 (each within the scatter of the next, the first and the last beyond it). At a limit, above all of these: compound 2.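

At this aromatic carbon of the shared core, cyano in place of 2-((pyridin-4-yl)oxy)ethyl gives a 1.5-fold lower number from compound 1 to compound 4 (0.17 log units; within the scatter) in this assay, so compound 1 and compound 4 are treated as equal. The series thus gains its first readable step at this position: a group of 2 heavy atoms with no ring and a group of 9 heavy atoms with a six-membered aromatic ring sit level here, so in this pair the chain and its ring are not needed for the number seen. Nothing available on the compounds accounts for this level result.

On these data alone, whether an amine or a carboxylic acid on this carbon would also stay level remains open. One step also leaves open whether the same holds with other substituents elsewhere on the core.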